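A few compounds are considered here, and "the series" means these few. Any claim that something is new, unique, unknown or untested is made for them only; others in the source may bear on it.

Measured so far: compound 2 `COc1ccc(Br)cc1CCc1c(Cl)cccc1-c1nccn1CC1CC1` with 2000 nM in an assay on isolated protein for binding affinity to Melanocortin receptor 4 (Homo sapiens); a lower number here means a stronger inhibitor, a higher number a weaker inhibitor; compound 1 `CCCn1ccnc1-c1cccc(Cl)c1CCc1cc(Br)ccc1OC` with 1300 nM in this assay.

Compound 2 has the highest of the two numbers, but the step of a 1.5-fold higher number from compound 1 to compound 2 (0.19 log units; within the scatter) shows that compound 1 and compound 2 cannot be told apart on these data.

Compound 3 `COc1ccc(Br)cc1CCc1c(Cl)cccc1-c1ncc2n1CCC2` differs from compound 2 by a group of 8 heavy atoms (6 carbon, 2 nitrogen; one five-membered non-aromatic ring with 1 hetero atom, one five-membered aromatic ring with 2 hetero atoms) in place of a group of 9 heavy atoms (7 carbon, 2 nitrogen; one three-membered non-aromatic ring of carbon only, one five-membered aromatic ring with 2 hetero atoms), on an aromatic carbon. Among the measured compounds shown here, the only measured step, from compound 1 to compound 2, swaps one substituent on the saturated chain carbon bound to the aromatic nitrogen; the change to compound 3 instead ties that chain back into a five-membered non-aromatic ring, which no measured pair covers. With only a within-scatter step available, no direction beyond the scatter is expected, so the estimated step of a 1.1-fold lower number from compound 2 to compound 3 (0.05 log units; within the scatter) is small. Compound 3 is therefore estimated at 1800 nM in this assay, within a range of 500 nM to 6000 nM.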

Compound 3, inhibition constant: 180 nM
For compound 3 the middle estimate is 10-fold (1.00 log units) above the measured one; measured number outside the range, below it.
By their numbers in this assay, from the lowest: compound 3; then compounds 1 and 2 (each within the scatter of the next).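

In this assay, the two open chains on the aromatic nitrogen of compound 1 and compound 2 could not be told apart, so this position had shown no response. Tying the chain back into a five-membered non-aromatic ring with 1 hetero atom does produce a response, with an 11-fold lower number from compound 2 to compound 3 (1.05 log units; beyond the scatter) and a 7.2-fold lower number from compound 1 to compound 3 (0.86 log units; beyond the scatter), which makes compound 3 the strongest inhibitor of the three. Nothing measured here accounts for this effect of the ring closure.

From the compounds shown here alone, it remains open whether the effect needs a ring of exactly this size, or whether a six-membered ring closed in the same way would give a similar number. Also open, going by these compounds, is how a methyl or hydroxyl group on the new ring would change the result.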